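Dropping One Methoxy Group from a Trimethoxyphenyl Compound

The source may hold more compounds than are shown below. What is called first, only, known or untested is meant among the compounds shown, and "the series" means these compounds.

Measured so far:
compound 1 `COc1cc(/C(Cl)=C/C=C(\C#N)C(=O)c2c[nH]c3ccccc23)cc(OC)c1OC`: 4000 nM
compound 2 `COc1ccc(/C(Cl)=C/C=C(\C#N)C(=O)c2c(C)[nH]c3ccccc23)cc1`: 56700 nM
compound 3 `COc1cc(/C(Cl)=C/C=C(\C#N)C(=O)c2c[nH]c3ccc(Br)cc23)cc(OC)c1OC`: 30800 nM

Three compounds were tested in a functional assay on MCF7 cells (Homo sapiens) for cytotoxicity, read by sulforhodamine B assay, with a stated time of 48 h; on this read-out higher numbers stand for weaker inhibition of growth and lower numbers for stronger inhibition of growth. Compound 1 gives 4000 nM, the lowest number of the three. The closest is compound 3, where a 7.7-fold higher number from compound 1 to compound 3 (0.89 log units; beyond the scatter). For the measured compounds named here, compound 2 sits furthest away with 56700 nM; it differs from compound 1 in two places at once, so no single step links them.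

The new compound is compound 4 `COc1ccc(/C(Cl)=C/C=C(\C#N)C(=O)c2c[nH]c3ccccc23)cc1OC`. Relative to compound 1 the change is hydrogen in place of methoxy on an aromatic carbon. Going by the values given here, none of the measured steps alters a methoxy group, so nothing here shows directly what this change does. What can be said is that both departures from compound 1 that were measured, in compound 3 and in compound 2, gave higher numbers in this assay. Taking that as a rough guide, a modest rise is expected, meaning weaker inhibition of growth. Compound 4 is expected to give 12000 nM, with a plausible range from 4000 nM to 40000 nM. The step this estimate implies is a 3.0-fold higher number from compound 1 to compound 4 (0.48 log units; beyond the scatter).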

Compound 4, concentration for 50% growth inhibition: 44200 nM
Beside the measured number, compound 4's estimate is 3.7-fold (0.57 log units) below it; measured number above the stated range.
By their numbers in this assay, from the lowest: compound 1; then compounds 3, 4 and 2 (each within the scatter of the next).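

This methoxy group, on an aromatic carbon ortho to a methoxy group and meta to both a large group and another methoxy group, clearly matters in this assay: replacing it with hydrogen gives an 11-fold higher number from compound 1 to compound 4 (1.04 log units; beyond the scatter). For the compounds shown here, this is the first direct reading of a change to the methoxy groups, and a single such change is enough to weaken growth inhibition well beyond the scatter. No measurement shown here explains the loss.

A hydroxy group, a fluorine atom or a longer ethoxy chain on this same carbon would help show whether the number depends on the methoxy group specifically or on having any group there. On these data alone, it also remains open whether removing either of the other methoxy groups from compound 1 would give a similar rise.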